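Benzyl for allyl on a thioether chain: an untested move

The source may report more compounds than this note shows. Statements on the series, on what has been measured and on what is new or still open speak of the compounds shown alone.

Two cysteine-derived methyl esters have so far been tested for their ability to oppose signalling through an assay on RAW264.7 cells for antagonist activity at Toll-like receptor 2 (Mus musculus), read by Griess assay, with a stated time of 24 h; on this read-out higher numbers stand for weaker inhibition and lower numbers for stronger inhibition. Compound 1, `C=CCCCSC[C@H](N)C(=O)OC`, gives 31300 nM. Compound 2, `C=CCSC[C@H](NC(=O)c1cc(OC)c(OC)c(OC)c1)C(=O)OC`, which carries a trimethoxybenzoyl amide on the nitrogen, gives 49300 nM. Among the two numbers compound 2 has the higher one, yet its gap to compound 1 lies within the usual scatter, so nothing can be said about which of the two inhibits more strongly.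

Compound 3, `COC(=O)[C@H](CSCc1ccccc1)NC(=O)c1cc(OC)c(OC)c(OC)c1`, has not been measured. It keeps the amide and the ester of compound 2 and differs from it in one place: phenyl in place of vinyl on a saturated chain carbon bound to a sulfur. Among the compounds with values here, no step between measured compounds covers a change of this kind, so there is nothing to gauge the size of it against. The two values in hand sit close together, and on that basis only a modest movement is expected in this assay, if any beyond the scatter, and if any, toward stronger inhibition. The step of a 1.6-fold lower number from compound 2 to compound 3 (0.22 log units; within the scatter) is therefore expected to be small. Compound 3 is estimated at 30000 nM, within a range of 10000 nM to 100000 nM.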

Compound 3, half-maximal inhibitory concentration: 32700 nM
The estimate for compound 3 lay 1.1-fold (0.04 log units) below the measured number; low and high end bracket the measured number.
By their numbers in this assay, from the lowest: compounds 1, 3 and 2 (each within the scatter of the next).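

In this assay, within the data shown here, phenyl in place of vinyl on a saturated chain carbon bound to a sulfur gives a 1.5-fold lower number from compound 2 to compound 3 (0.18 log units; within the scatter) and is the first change between measured compounds that can be read at this position. Its result is that the allylsulfanyl and benzylsulfanyl forms cannot be told apart on this read-out, even though the change brings in a six-membered aromatic ring of carbon only where a double bond outside aromatic rings stood. The compounds offer nothing that explains why the two forms read alike.

On these data alone, it remains open whether any other group at this place would move the value beyond the scatter, for instance a benzyl group bearing an amine or a carboxylic acid, or a longer chain in place of benzyl. No pair among the compounds shown differs only on the nitrogen, so what the trimethoxybenzoyl amide contributes, and whether a smaller acyl group or a free carboxylic acid in place of the methyl ester would matter, cannot yet be read.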